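The compounds below may be only part of what the source reports. "The series", "measured", "known", "first", "only" and "open" are said of these compounds alone.

Measured so far:
Compound 1 `COc1cccc(/C=C2\CCC/C(=C\c3ccccc3Cl)C2=O)c1OC`: in a functional assay on A549 cells (Homo sapiens) for cytotoxicity, read by MTT assay, with a stated time of 72 h (a lower number here means a stronger inhibitor, a higher number a weaker inhibitor), compound 1 gives > 20000 nM, a limit of the assay.
Compound 2 `COc1ccccc1/C=C1\CCC/C(=C\c2cccc(OC)c2OC)C1=O`: compound 2 gives > 20000 nM, a limit of the assay.
Compound 3 `COc1ccc(/C=C2\CCC/C(=C\c3ccc(O)c(Cl)c3)C2=O)cc1OC`: compound 3 gives > 20000 nM, a limit of the assay.

Within the data shown here, the one change made twice in this set is methoxy in place of chloro on an aromatic carbon. Between the measured pair it gives a step that the two limits leave unreadable from compound 1 to compound 2, which rests on (the limit of > 20000 nM in this assay, at which 3 of the 3 values shown sit). Compound 4 `COc1cc(/C=C2\CCC/C(=C\c3ccc(OC)c(OC)c3)C2=O)ccc1O` carries the same kind of change relative to compound 3, namely (methoxy in place of chloro on an aromatic carbon); the surroundings differ, the first being ortho to a large group, the second ortho to a hydroxy group (1 heavy atom) and meta to a large group. The difference between the cores of compound 1 and compound 3 is not broken down here. The step from compound 3 is expected as a step that the limit leaves unreadable from compound 3 to compound 4, beside the unreadable earlier one. Compound 4 is estimated at 30000 nM, most likely again a limit.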

Compound 4, half-maximal inhibitory concentration: 10300 nM
Estimate against measurement, compound 4: 2.9-fold (0.46 log units) above; the measured number falls inside the stated range.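

In this assay, replacing chloro with methoxy in the 3-chloro-4-hydroxyphenyl group gives an at least 1.9-fold lower number from compound 3 to compound 4 (0.28 log units; that floor lies within the scatter). Among these compounds, compound 4 gives 10300 nM, the only value shown that is not a limit. This step does not by itself establish a change beyond the scatter. The steps that rest on limits alone cannot be read, so the data do not show whether the change carries over from the core of compound 1 to the core of compound 3: the limit of > 20000 nM in this assay, at which 3 of the 4 values shown sit.

Still open, as far as these compounds go, is how an amine or a carboxylic acid would read on the aromatic carbon that carries the methoxy of compound 4. From the compounds shown here alone, a longer chain such as ethoxy on that carbon is equally open.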